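Aryl substitution on the shared core: compounds 1 to 4

The compounds below may be only part of what the source reports. "The series", "measured", "known", "first", "only" and "open" are said of these compounds alone.

Measured in a functional assay on KM12 cells (Homo sapiens) for inhibition, read by sulforhodamine B assay, with a stated time of 48 h, tested at 10 uM; on this read-out lower numbers stand for less inhibition and higher numbers for more inhibition at the one concentration tested (going by the name of the read-out):
- compound 1 `c1ccc(-c2cn3ccnc3c(-c3ccc4ncn(C5CCCCC5)c4c3)n2)cc1`: 49%
- compound 2 `Fc1ccc(-c2cn3ccnc3c(-c3ccc4ncn(C5CCCCC5)c4c3)n2)cc1`: 3.49%
- compound 3 `Brc1ccc(-c2cn3ccnc3c(-c3ccc4ncn(C5CCCCC5)c4c3)n2)cc1`: 23.3%

Compound 2 stands lowest of the three in this assay; its nearest neighbour is compound 3, and the gap to compound 1 is the largest in the set. The steps among the measured compounds are a number 45.5 percentage points lower from compound 1 to compound 2 (beyond the scatter), a number 25.7 percentage points lower from compound 1 to compound 3 (beyond the scatter) and a number 19.8 percentage points higher from compound 2 to compound 3 (beyond the scatter).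

Compound 4 `COc1ccccc1-c1cn2ccnc2c(-c2ccc3ncn(C4CCCCC4)c3c2)n1` has not yet been measured. It differs from compound 2 as follows: 2-methoxyphenyl in place of 4-fluorophenyl on an aromatic carbon. For the measured compounds named here, no measured step involves a 2-methoxyphenyl group, so the bearing of the data is indirect. Both steps that touch compound 2 point the same way: leaving the 4-fluorophenyl group raised the number in a number 19.8 percentage points higher from compound 2 to compound 3 (beyond the scatter), and compound 1, without the fluoro, gives 49%. On that basis a step upward beyond the scatter is expected, of the size a number 26.5 percentage points higher from compound 2 to compound 4 (beyond the scatter). The expected value for compound 4 in this assay is 30%, with a range from 5% to 55%.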

Compound 4, a percentage reported as inhibition, at one concentration (the size of the read-out at that concentration, not a potency): 3.58%
Beside the measured number, compound 4's estimate is 26.4 percentage points above it; the measured number lies below the stated range.
By their numbers in this assay, from the lowest: compounds 2 and 4 (each within the scatter of the next); then compound 3; then compound 1.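

In this assay the step of a number 0.1 percentage points higher from compound 2 to compound 4 (within the scatter) shows that 4-fluorophenyl and 2-methoxyphenyl cannot be told apart at this aromatic carbon, so a low number here is not tied to the fluoro group alone. The readings a number 45.4 percentage points lower from compound 1 to compound 4 (beyond the scatter) and a number 19.7 percentage points lower from compound 3 to compound 4 (beyond the scatter) place compound 4 well under the unsubstituted phenyl of compound 1 and also under the 4-bromophenyl of compound 3, and with this result all three substituted phenyl groups stand under compound 1, with none going against that. No available data bear on why these steps arise.

On these data alone, it remains open whether the identity of the substituent or its place on the phenyl ring sets the number, since methoxy appears only as 2-methoxyphenyl and the halogens only as 4-substituted phenyl groups. As far as these compounds go, how an amine or a carboxylic acid on this phenyl ring would read also stays open.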